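The compounds below may be only part of what the source reports. "The series", "measured", "known", "first", "only" and "open" are said of these compounds alone.

- compound 1 `CCC(=O)NCc1cccc(C(=O)Nc2ccc(C)c(Nc3nccc(-c4cccnc4)n3)c2)c1`: 4750 nM
- compound 2 `CCC(=O)Nc1ccc(C(=O)Nc2ccc(C)c(Nc3nccc(-c4cccnc4)n3)c2)cc1`: > 10000 nM (a limit)
- compound 3 `CCC(=O)Nc1cc(C(=O)Nc2ccc(C)c(Nc3nccc(-c4cccnc4)n3)c2)cc(C(F)(F)F)c1`: > 10000 nM (a limit)

All three compounds were tested in an ADME assay on BaF3 cells (Mus musculus) for cytotoxicity, read by CellTiter-Glo and CCK-8 assay, with a stated time of 72 h; on this read-out higher numbers stand for weaker inhibition of growth and lower numbers for stronger inhibition of growth. Compound 2 gives > 10000 nM, which is a limit of the assay and not a number. Compound 3 gives > 10000 nM, which is also a limit. Compound 1, with 4750 nM, is the only one of the three to give a number. Going by the values given here, no step between measured compounds is available, so the series offers no measured size of effect for a single change.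

The next compound is compound 4 `Cc1ccc(NC(=O)c2ccc(CN(CCN(C)C)C(=O)C3CC3)cc2)cc1Nc1nccc(-c2cccnc2)n1`, which differs from compound 2 as follows: ((cyclopropylcarbonyl)(2-(dimethylamino)ethyl)amino)methyl in place of propanoylamino on an aromatic carbon. In words, ((cyclopropylcarbonyl)(2-(dimethylamino)ethyl)amino)methyl stands in place of propanoylamino on an aromatic carbon of a six-membered aromatic ring of carbon only, para to a large group.

A modest step of an at least 1.6-fold lower number from compound 2 to compound 4 (0.22 log units; that floor lies within the scatter) is expected, toward stronger inhibition of growth. This expectation rests on compound 1 at 4750 nM, which shows that the series can give a number in this assay. A reported limit for compound 4 also remains possible because of the limit of > 10000 nM in this assay, at which 2 of the 3 values shown sit. Compound 4 is estimated at 6000 nM, with an expected range of 2000 nM to 10000 nM.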

Compound 4, concentration for 50% growth inhibition: > 10000 nM
Compound 4 ended at the assay's limit; the forecaster's own chance of this, stated with the estimate: 40%; middle value at least 1.6-fold (0.22 log units) away from the limit.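

Compound 2 and compound 4 both stand at a limit in this assay, so no step between them can be read: the limit of > 10000 nM in this assay, at which 3 of the 4 values shown sit.

The compounds shown leave open whether ((cyclopropylcarbonyl)(2-(dimethylamino)ethyl)amino)methyl in place of propanoylamino changes growth inhibition at all, since only compound 1 gives a number, 4750 nM.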